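The source may hold more compounds than are shown below. What is called first, only, known or untested is meant among the compounds shown, and "the series" means these compounds.

Working notes on the series. Of the compounds shown here, three have been measured in a functional assay on MCF7 cells (Homo sapiens) for cytotoxicity, read by MTT assay, with a stated time of 48 h; a higher number here means a weaker inhibitor, a lower number a stronger inhibitor: compound 1 `CCCCCCCCCCCCNC(=O)[C@@H](NC(=O)c1ccco1)[C@@H](C)O`, compound 2 `CCCCCCCCCCCCNC(=O)[C@@H](NC(=O)c1cccs1)[C@@H](C)O` and compound 3 `CCCCCCCCCCCCCCCCCCNC(=O)[C@@H](NC(=O)c1ccco1)[C@@H](C)O`. In this assay compound 1 gives 67500 nM, compound 2 gives 30400 nM and compound 3 gives 21400 nM. The change thiophen-2-yl in place of furan-2-yl on a carbonyl carbon brought a 2.2-fold lower number from compound 1 to compound 2 (0.35 log units; beyond the scatter). The change hexyl in place of hydrogen on a saturated chain carbon, ten or more bonds along the chain from an amide-type nitrogen brought a 3.2-fold lower number from compound 1 to compound 3 (0.50 log units; beyond the scatter). Compound 3 has the lowest of the three numbers; its gap to compound 2 lies within the scatter, its gap to compound 1 beyond it.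

Compound 4 `CCCCCCCCCCCCCCCCCCNC(=O)[C@@H](NC(=O)c1cccs1)[C@@H](C)O` has not been measured. For the measured compounds named here, it differs from compound 3 by thiophen-2-yl in place of furan-2-yl on a carbonyl carbon, the same change as the one made from compound 1 to compound 2, since the place reads the same in both; the two cores differ by the hexyl change just described. The change occurs twice in all, once measured. The step of a 1.9-fold lower number from compound 3 to compound 4 (0.29 log units; within the scatter) is expected to be of similar size to the earlier one, resting on the single measured occurrence a 2.2-fold lower number from compound 1 to compound 2 (0.35 log units; beyond the scatter) and tempered only by that being a single case. Compound 4 is therefore estimated at about 11000 nM in this assay, expected between 5000 nM and 25000 nM.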

Compound 4, half-maximal inhibitory concentration: 25700 nM
Estimate against measurement, compound 4: 2.3-fold (0.37 log units) below, and the stated range ends below it.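

On the core of compound 3, thiophen-2-yl in place of furan-2-yl gives a 1.2-fold higher number from compound 3 to compound 4 (0.08 log units; within the scatter) in this assay, so the step seen on the core of compound 1 does not carry over at its earlier size: the same change on two cores in this assay, a 2.2-fold lower number (0.35 log units; beyond the scatter) from compound 1 to compound 2 and a 1.2-fold higher number (0.08 log units; within the scatter) from compound 3 to compound 4, 2.7-fold (0.43 log units) apart, beyond the scatter of two such steps

The hexyl change, read on the thiophen-2-yl side, gives a 1.2-fold lower number from compound 2 to compound 4 (0.07 log units; within the scatter) and likewise falls short of its size on the furan-2-yl side: the same change on two cores in this assay, a 3.2-fold lower number (0.50 log units; beyond the scatter) from compound 1 to compound 3 and a 1.2-fold lower number (0.07 log units; within the scatter) from compound 2 to compound 4, 2.7-fold (0.43 log units) apart, beyond the scatter of two such steps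

Both comparisons rest on the same four compounds and show that in this series the two changes do not add up, so a step measured on one core is a poor guide to the other; they do not show why, or how either change would behave on a further core.

Going by these compounds, compounds 2, 3 and 4 lie within the scatter of each other, and whether this marks a floor in this assay remains open. A chain longer than that of compound 3, or a phenyl group in place of the five-membered ring on the carbonyl, would test this.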